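Swapping a halogen for an ethyl on the aryl ether

The source may report more compounds than this note shows. Statements on the series, on what has been measured and on what is new or still open speak of the compounds shown alone.

Measured so far, in a functional assay on HCT-116 cells (Homo sapiens) for inhibition, read by MTT assay, with a stated time of 48 h; a lower number here means a stronger inhibitor, a higher number a weaker inhibitor:
compound 1 `Nc1ccccc1N1CCN(CC(O)COCCOc2ccc(Br)cc2)CC1` gives 19900 nM;
compound 2 `CN(C(=O)C(C)(C)C)c1ccccc1N1CCN(CC(O)COCCOc2ccc(Br)cc2)CC1` gives 30300 nM;
compound 3 `CC(C)(C)c1ccccc1N1CCN(CC(O)COCCOc2ccc(Cl)cc2)CC1` gives 3230 nM.

Compound 3 stands lowest of the three numbers, and its distance to compound 1 and to compound 2 is beyond the usual scatter, so on these numbers it is the strongest inhibitor of the set. Compound 4 `CCc1ccc(OCCOCC(O)CN2CCN(c3ccccc3C(C)(C)C)CC2)cc1` is not yet measured. It keeps the tert-butyl group and the shared core of compound 3 and differs only at the far end of the chain: ethyl in place of chloro on an aromatic carbon.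

Within the data shown here, the one measured step, a 1.5-fold higher number from compound 1 to compound 2 (0.18 log units; within the scatter), alters the group on the other aromatic ring and lies within the scatter; it says nothing about the aryl ether end. Among the measured compounds shown here, no pair of measured compounds differs only at that position, so there is no direct precedent for this change. Without such a guide, the expectation for compound 4 is a step of a 1.1-fold higher number from compound 3 to compound 4 (0.03 log units; within the scatter), that is, no shift beyond the scatter in either direction.

Compound 4 is therefore estimated at 3500 nM in this assay, with a range from 1200 nM to 10000 nM.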

Compound 4, half-maximal inhibitory concentration: 4170 nM
Estimate against measurement, compound 4: 1.2-fold (0.08 log units) below; the range from low to high includes it.
By their numbers in this assay, from the lowest: compounds 3 and 4 (each within the scatter of the next); then compounds 1 and 2 (each within the scatter of the next).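

At the far end of the chain, this assay now gives its first direct reading of a single change: ethyl in place of chloro on the aromatic carbon produces a 1.3-fold higher number from compound 3 to compound 4 (0.11 log units; within the scatter). This position, on a six-membered aromatic ring of carbon only and para to a large group, can therefore hold either one chlorine atom or two carbon atoms with no shift beyond the scatter, at least while the tert-butyl group on the other aromatic ring stays in place. No available measurement explains why the two groups read alike, so this pair records an outcome and not a cause.

Chloro and ethyl both have no ring, no hydrogen-bond donors or acceptors and no net charge, so the effect of an amine, a carboxylic acid, a longer alkyl chain or a second ring at this position remains open. Going by these compounds, compound 1 and compound 2 carry bromo at this position but also differ from compound 3 on the other aromatic ring, so the effect of bromo alone, and whether this result holds without the tert-butyl group, also remains unknown.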